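The source may hold more compounds than are shown below. What is called first, only, known or untested is meant among the compounds shown, and "the series" means these compounds.

Working notes on the series in a functional assay on MKN-45 cells (Homo sapiens) for cytotoxicity, read by MTT assay, with a stated time of 72 h; on this read-out higher numbers stand for weaker inhibition and lower numbers for stronger inhibition. Of the compounds shown here, two have been measured. Compound 1 `COc1cc2c(Oc3ccc(NC(=O)c4nnn(-c5ccc(F)c(F)c5)c4C(F)(F)F)cc3F)ccnc2cc1OCCCN1CCCCC1` gives 90 nM in this assay. Compound 2 `COc1cc2c(Oc3ccc(NC(=O)c4nnn(-c5ccccc5Cl)c4C(F)(F)F)cc3F)ccnc2cc1OCCCN1CCN(C)CC1` gives 166 nM in this assay; this is the higher of the two numbers, but the gap to compound 1 lies within the scatter, so no order between compound 1 and compound 2 is claimed. Among the compounds with values here, compound 1 and compound 2 differ from each other in more than one place, in the aryl group on the five-membered aromatic ring with 3 nitrogen and in the chain carrying the amine, so no single step between measured compounds is available.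

Compound 3 `COc1cc2c(Oc3ccc(NC(=O)c4nnn(-c5ccc(F)c(F)c5)c4C(F)(F)F)cc3F)ccnc2cc1OCCCN1CCN(C)CC1` is not yet measured. It differs from compound 2 in one place: 3,4-difluorophenyl in place of 2-chlorophenyl on an aromatic nitrogen. Compound 3 therefore carries the aryl group of compound 1 on the chain of compound 2. Within the data shown here, the only guide is that compound 1 and compound 2, which differ in both places at once, give numbers within the scatter of each other. Because compound 1 gives 90 nM and compound 2 gives 166 nM, the step from compound 2 to compound 3 is expected to be a 1.5-fold lower number from compound 2 to compound 3 (0.18 log units; within the scatter), not beyond the scatter and if anything toward lower numbers. Compound 3 is expected at 110 nM, with a range of 50 nM to 250 nM.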

Compound 3, half-maximal inhibitory concentration: 90 nM
Compound 3: the middle estimate sits 1.2-fold (0.09 log units) above what was measured, within the range that was stated.
By their numbers in this assay, from the lowest: compounds 1, 3 and 2 (each within the scatter of the next).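

With the 4-methylpiperazin-1-yl chain held fixed, 3,4-difluorophenyl in place of 2-chlorophenyl on the aromatic nitrogen of the five-membered ring gives a 1.8-fold lower number from compound 2 to compound 3 (0.27 log units; within the scatter) in this assay, so the two aryl groups are not told apart at this position in this assay. With 3,4-difluorophenyl held fixed, 4-methylpiperazin-1-yl in place of piperidin-1-yl on the saturated chain carbon gives no change at the digits printed from compound 1 to compound 3 (within the scatter), so each of the two places can now be read alone, and neither exchange moves the number beyond the scatter. No measurement at hand accounts for either step.

Still open, as far as these compounds go, is how far this holds on the aromatic nitrogen for other groups, such as unsubstituted phenyl, 4-methoxyphenyl or a saturated ring such as cyclohexyl. Also open, from the compounds shown here alone, are other amines on the chain, such as morpholine or dimethylamine, a longer or shorter chain, and a methyl group or a hydrogen on the ring atom that bears the trifluoromethyl group.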